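The source may report more compounds than this note shows. Statements on the series, on what has been measured and on what is new or still open speak of the compounds shown alone.

In a functional assay on HeLa cells (Homo sapiens) for antiproliferative activity, read by cell counting, with a stated time of 2 days (on this read-out lower numbers stand for stronger inhibition and higher numbers for weaker inhibition), compound 1 (`COc1ccc(Nc2nc(N)c(C(=O)c3ccc(OC)c(OC)c3)s2)cc1`) gives 52 nM and compound 2 (`COc1cc(C(=O)c2sc(Nc3ccc(Cl)cc3)nc2N)cc(OC)c1OC`) gives 180 nM, the higher of the two numbers, with the gap beyond the scatter. Compound 3 (`COc1ccc(Nc2nc(N)c(C(=O)c3cc(OC)c(OC)c(OC)c3)s2)cc1`) differs from compound 2 by methoxy in place of chloro on an aromatic carbon, para to a large group: methoxy in place of chloro on an aromatic carbon. It thereby gains the (4-methoxyphenyl)amino group of compound 1, which stands at 52 nM. For the measured compounds named here, no measured step isolates this change, so the expectation is tentative: a lower number, beyond the scatter, with an estimated 3.6-fold lower number from compound 2 to compound 3 (0.56 log units; beyond the scatter). Compound 3 is expected at 50 nM, with an estimated range of 15 nM to 170 nM.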

Compound 3, half-maximal inhibitory concentration: 560 nM
Compound 3: the middle estimate sits 11-fold (1.05 log units) below what was measured; measured number outside the range, above it.
By their numbers in this assay, from the lowest: compound 1; then compound 2; then compound 3.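

In this assay, methoxy in place of chloro on an aromatic carbon, para to a large group, gives a 3.1-fold higher number from compound 2 to compound 3 (0.49 log units; beyond the scatter), so 4-methoxyphenyl does not beat 4-chlorophenyl on this background. The (4-methoxyphenyl)amino group alone therefore does not secure a low number: with that group present on both sides, an extra methoxy gives an 11-fold higher number from compound 1 to compound 3 (1.03 log units; beyond the scatter), the larger of the two steps. Nothing at hand accounts for either step. Still open, as far as these compounds go, is how a methyl group, fluoro or a dimethylamino group would stand in place of chloro, and whether the chloro-to-methoxy step keeps its direction on the core of compound 1.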